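From Bromo to Acetyl: A Step Still Unmeasured

A few compounds are considered here, and "the series" means these few. Any claim that something is new, unique, unknown or untested is made for them only; others in the source may bear on it.

Of the compounds shown here, three sharing one core have been tested in a functional assay on PC-3 cells (Homo sapiens) for inhibition, read by MTT assay, with a stated time of 48 h; a lower number here means a stronger inhibitor, a higher number a weaker inhibitor. Compound 1 (`COc1cc(Nc2nc(Nc3ccc(Cl)cc3)nnc2Cl)cc(OC)c1OC`) gives 9610 nM, compound 2 (`CCOC(=O)c1ccc(Nc2nnc(Cl)c(Nc3cc(OC)c(OC)c(OC)c3)n2)cc1`) gives 58500 nM, and compound 3 (`COc1cc(Nc2nc(Nc3ccc(Br)cc3)nnc2Cl)cc(OC)c1OC`) gives 8990 nM. Compound 3 therefore sits level with compound 1, as a 1.1-fold lower number from compound 1 to compound 3 (0.03 log units; within the scatter) lies within the scatter, while compound 2 stands apart, with a 6.5-fold lower number from compound 2 to compound 3 (0.81 log units; beyond the scatter).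

Compound 4 (`COc1cc(Nc2nc(Nc3ccc(C(C)=O)cc3)nnc2Cl)cc(OC)c1OC`) has acetyl in place of bromo on an aromatic carbon, para to a large group: acetyl in place of bromo on an aromatic carbon. Going by the values given here, no measured step makes this exact exchange. The closest evidence comes from compound 2, whose ethoxycarbonyl group also contains a carbonyl. Its modest steps are a 6.1-fold higher number from compound 1 to compound 2 (0.78 log units; beyond the scatter) and a 6.5-fold lower number from compound 2 to compound 3 (0.81 log units; beyond the scatter), whereas swapping one halogen for the other changed nothing measurable. Acetyl is not ethoxycarbonyl, so only part of that shift is expected to carry over, in the same direction towards a weaker inhibitor. The expected modest move is a 2.8-fold higher number from compound 3 to compound 4 (0.44 log units; beyond the scatter). Compound 4 is estimated at 25000 nM, with an expected range of 9000 nM to 65000 nM.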

Compound 4, half-maximal inhibitory concentration: 38600 nM
For compound 4 the middle estimate is 1.5-fold (0.19 log units) below the measured one, and the stated range covers the measured number.
By their numbers in this assay, from the lowest: compounds 3 and 1 (each within the scatter of the next); then compounds 4 and 2 (each within the scatter of the next).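

In this assay, going by these compounds alone, acetyl on an aromatic carbon, para to a large group, gives a weaker inhibitor than either halogen (a 4.3-fold higher number from compound 3 to compound 4 (0.63 log units; beyond the scatter); a 4.0-fold higher number from compound 1 to compound 4 (0.60 log units; beyond the scatter)), so ethoxycarbonyl is no longer the only carbonyl-bearing group that separates from chloro and bromo. Methyl in place of ethoxy on the carbonyl carbon opens no gap that can be told from the scatter (a 1.5-fold lower number from compound 2 to compound 4 (0.18 log units; within the scatter)), so the two carbonyl-bearing groups read alike at this position. Nothing available explains why these groups differ from the halogens.

With only two halogens and two carbonyl-bearing groups shown, the split rests on four compounds. The compounds leave open whether a carboxylic acid, an amide or an amine at this position would stand with the carbonyl-bearing groups or with the halogens.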